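The source may hold more compounds than are shown below. What is called first, only, known or untested is meant among the compounds shown, and "the series" means these compounds.

Measured compounds in a functional assay on NCI-H460 cells (Homo sapiens) for antiproliferative activity, read by MTT assay, with a stated time of 72 h; on this read-out higher numbers stand for weaker inhibition and lower numbers for stronger inhibition:
compound 1 `CNC(=O)c1cc(Oc2ccc(NC(=O)c3cc4cccnc4n(-c4ccccc4)c3=O)cc2)ccn1`: 320 nM
compound 2 `CCNC(=O)c1cc(Oc2ccc(NC(=O)c3cc4cccnc4n(-c4ccccc4)c3=O)cc2)ccn1`: 1120 nM

Compound 2 gives the highest of the two numbers in this assay; its nearest neighbour is compound 1, and the step of a 3.5-fold higher number from compound 1 to compound 2 (0.54 log units; beyond the scatter) lies beyond the usual scatter. Compound 3 `CCCNC(=O)c1cc(Oc2ccc(NC(=O)c3cc4cccnc4n(-c4ccccc4)c3=O)cc2)ccn1` has not yet been measured in this assay. It differs from compound 2 by methyl in place of hydrogen on a saturated chain carbon, two bonds along the chain from an amide-type nitrogen, so the ethyl on the amide becomes a propyl. Going by the values given here, the only measured step that bears on this change is the one in which methyl replaced hydrogen on the chain carbon bound to the amide nitrogen, a 3.5-fold higher number from compound 1 to compound 2 (0.54 log units; beyond the scatter). Lengthening the chain once more is a change of the same kind, cut one bond further out, so a further weakening of inhibition is expected, though two measured compounds alone cannot show whether the second lengthening costs as much as the first. The expected step is a 2.0-fold higher number from compound 2 to compound 3 (0.29 log units; within the scatter), a rise of modest size. On that basis compound 3 is estimated at 2200 nM in this assay, with a range from 800 nM to 6500 nM.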

Compound 3, half-maximal inhibitory concentration: 110 nM
Compound 3: middle estimate off by 20-fold (1.30 log units), on the high side, outside the stated range (below it).
By their numbers in this assay, from the lowest: compound 3; then compound 1; then compound 2.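

In this assay the chain on the amide nitrogen does not follow a one-way trend: the same kind of change, a methyl in place of a hydrogen, gives a 3.5-fold higher number from compound 1 to compound 2 (0.54 log units; beyond the scatter) at the chain carbon bound to the amide nitrogen but a 10-fold lower number from compound 2 to compound 3 (1.01 log units; beyond the scatter) two bonds along the chain. The propyl chain also beats the shorter methyl chain, with a 2.9-fold lower number from compound 1 to compound 3 (0.46 log units; beyond the scatter) as the net result, so a longer chain does not by itself mean weaker inhibition, and compound 2 with its ethyl chain gives the weakest inhibition of the three. Nothing in the available data explains why the ethyl chain falls out of line with its two neighbours.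

Going by these compounds, whether the gain continues with a longer chain such as butyl, or survives branching to isopropyl or closing the chain to cyclopropyl, remains open. Also open, on these data alone, is whether an amine or a hydroxyl at the end of the propyl chain would keep the inhibition of compound 3, and whether the same order of the three compounds holds in other cell lines.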